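The source may report more compounds than this note shows. Statements on the series, on what has been measured and on what is new or still open speak of the compounds shown alone.

Measured in a functional assay on HCT-116 cells (Homo sapiens) for antiproliferative activity, read by MTT assay, with a stated time of 72 h; a lower number here means a stronger inhibitor, a higher number a weaker inhibitor:
- compound 1 `Nc1nc(N)c2cc(CSC(=S)N3CCN(C4CCCCC4)CC3)ccc2n1`: 8400 nM
- compound 2 `COc1ccc(N2CCN(C(=S)SCc3ccc4nc(N)nc(N)c4c3)CC2)cc1`: 2270 nM
- compound 3 `Cc1ccc(N2CCN(C(=S)SCc3ccc4nc(N)nc(N)c4c3)CC2)c(C)c1`: 4070 nM

Compound 3 has one close neighbour among these numbers and one further off. The series shows a 1.8-fold higher number from compound 2 to compound 3 (0.25 log units; within the scatter), and also a 2.1-fold lower number from compound 1 to compound 3 (0.31 log units; beyond the scatter).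

The next compound, compound 4 `Nc1nc(N)c2cc(CSC(=S)N3CCN(c4ccc(F)cc4)CC3)ccc2n1`, has 4-fluorophenyl in place of 2,4-dimethylphenyl on an amine nitrogen in a ring.

Going by the values given here, the closest precedent is the exchange of 4-methoxyphenyl for 2,4-dimethylphenyl at this same place, which did not move the number beyond the scatter. The modest steps of a 3.7-fold lower number from compound 1 to compound 2 (0.57 log units; beyond the scatter) and a 2.1-fold lower number from compound 1 to compound 3 (0.31 log units; beyond the scatter) bear less directly, since both start from cyclohexyl, which is not a phenyl group. Among the compounds with values here, no fluorinated compound has been measured yet, so the data give no direction for this change, and no step beyond the scatter is expected in this assay.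

The estimate therefore means an expected 1.2-fold lower number from compound 3 to compound 4 (0.09 log units; within the scatter). Compound 4 is expected at 3300 nM, with an estimated range from 1400 nM to 7500 nM.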

Compound 4, half-maximal inhibitory concentration: 3270 nM
For compound 4 the middle estimate is 1.0-fold (0.00 log units) above the measured one; the measured number falls inside the stated range.
By their numbers in this assay, from the lowest: compounds 2, 4 and 3 (each within the scatter of the next); then compound 1.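

In this assay the fluorine-bearing ring on this amine nitrogen cannot be told apart from the other two aromatic rings shown: replacing 2,4-dimethylphenyl with 4-fluorophenyl gives (a 1.2-fold lower number from compound 3 to compound 4 (0.10 log units; within the scatter)), and replacing methoxy with fluoro on the aromatic carbon gives (a 1.4-fold higher number from compound 2 to compound 4 (0.16 log units; within the scatter)). Compound 4 also joins compound 2 and compound 3 on the same side of the cyclohexyl compound (a 2.6-fold lower number from compound 1 to compound 4 (0.41 log units; beyond the scatter)), so all three phenyl-bearing compounds shown have lower numbers than compound 1, with none going against this. No evidence is available to explain these results.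

From the compounds shown here alone, whether this tolerance extends to a pyridine ring, a benzyl group or a phenyl ring carrying a carboxylic acid remains open. The compounds shown also leave open whether any group at this position can move the number beyond the scatter of compound 2.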